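Swapping the side chain on a shared core against lipase

The source may hold more compounds than are shown below. What is called first, only, known or untested is meant among the compounds shown, and "the series" means these compounds.

Of the compounds shown here, two with the same core have been measured in an assay (strain Wistar) for inhibition of Hormone-sensitive lipase (Rattus norvegicus), read by spectrophotometry; a lower number here means a stronger inhibitor, a higher number a weaker inhibitor. Compound 1 `COCCc1c(C)n(C(=O)N2CCC(c3ccccc3)CC2)oc1=O` gives 11 nM. Compound 2 `Cc1c(C(C)C)c(=O)on1C(=O)N1CCC(c2cccc(F)c2)CC1` gives 12 nM, a number that cannot be told apart from that of compound 1 within the usual scatter, so the two stand side by side. Compound 3 `COCCc1c(C)n(C(=O)N2CCC(c3cccc(F)c3)CC2)oc1=O` is the next compound, not yet measured. It differs from compound 2 in one spot: 2-methoxyethyl in place of isopropyl on an aromatic carbon. Among the measured compounds shown here, the same 2-methoxyethyl group is present in compound 1, which is as strong an inhibitor as compound 2, and no pair of measured compounds shows a step tied to this change alone. The step from compound 2 to compound 3 is therefore expected to be small, no change at the digits printed from compound 2 to compound 3 (within the scatter), with no direction beyond the scatter. For compound 3 the estimate in this assay is 12 nM, likely falling between 5 nM and 30 nM.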

Compound 3, half-maximal inhibitory concentration: 20 nM
Compound 3: the middle estimate sits 1.7-fold (0.22 log units) below what was measured, within the range that was stated.
By their numbers in this assay, from the lowest: compounds 1, 2 and 3 (each within the scatter of the next).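

In this assay, the 2-methoxyethyl and isopropyl groups can now be compared directly on an otherwise unchanged compound: the swap gives a 1.7-fold higher number from compound 2 to compound 3 (0.22 log units; within the scatter), so the two groups cannot be told apart at this position. The fluoro group also gets its first comparison of its own, with fluoro in place of hydrogen on an aromatic carbon giving a 1.8-fold higher number from compound 1 to compound 3 (0.26 log units; within the scatter), so this change cannot be told apart from the hydrogen in these compounds either. No supporting measurement is available to explain either result.

On these data alone, whether an amine, a carboxylic acid or a longer chain in place of 2-methoxyethyl would produce a step beyond the scatter remains open. So does whether chloro in place of fluoro would do so.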